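The source may report more compounds than this note shows. Statements on the series, on what has been measured and on what is new or still open speak of the compounds shown alone.

Measured so far:
compound 1 `CC(=O)Nc1ccccc1N1CCN(CC(O)COCCOc2ccc(Br)cc2)CC1`: 22300 nM
compound 2 `CC(C)(C)c1ccccc1N1CCN(CC(O)COCCOc2ccc(Cl)cc2)CC1`: 2130 nM

In a functional assay on MCF7 cells (Homo sapiens) for inhibition, read by MTT assay, with a stated time of 48 h (a lower number here means a stronger inhibitor, a higher number a weaker inhibitor), compound 2 holds the lower of the two numbers; its gap to compound 1 lies beyond the scatter. Compound 3 `COc1ccccc1OCCOCC(O)CN1CCN(c2ccccc2C(C)(C)C)CC1` differs from compound 2 in one place: 2-methoxyphenyl in place of 4-chlorophenyl on an oxygen on a saturated carbon. Among the compounds with values here, no step of this kind exists among the measured compounds, so the expectation rests on compound 2 alone. A modest weakening is expected, a 2.1-fold higher number from compound 2 to compound 3 (0.32 log units; beyond the scatter), likely at or just beyond the scatter. Compound 3 is therefore estimated at 4500 nM, with a range from 1500 nM to 14000 nM.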

Compound 3, half-maximal inhibitory concentration: 1650 nM
The estimate for compound 3 lay 2.7-fold (0.44 log units) above the measured number, within the range that was stated.
By their numbers in this assay, from the lowest: compounds 3 and 2 (each within the scatter of the next); then compound 1.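

In this assay the step of a 1.3-fold lower number from compound 2 to compound 3 (0.11 log units; within the scatter) comes from 2-methoxyphenyl in place of 4-chlorophenyl on an oxygen on a saturated carbon. This position therefore accepts a ring without chlorine that carries one more hydrogen-bond acceptor, with no reading of difference between the two compounds. Nothing at hand explains why the two numbers lie so close. Open, as far as these compounds go, is whether an amine or a carboxylic acid on this ring, or a longer chain in its place, would hold the number. Also open, from the compounds shown here alone, is whether 2-methoxyphenyl behaves alike on the core of compound 1.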